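Trifluoromethyl for Fluoro on a Phenoxy Ring

A few compounds are considered here, and "the series" means these few. Any claim that something is new, unique, unknown or untested is made for them only; others in the source may bear on it.

Compound 3 `CC(Oc1ccc(Oc2ccc(F)cc2)cc1)C(=O)Cn1nnc(-c2ccccc2)n1` has been tested in an ADME assay on S9 fraction from liver (Rattus norvegicus) for metabolic stability, read by LC-MS, using NADPH, with a stated time of 30 min (on this read-out lower numbers stand for a less stable compound and higher numbers for a more stable compound), where it gives < 5%; that figure is a limit of the assay, not a number. Compound 4 `CC(Oc1ccc(Oc2ccc(C(F)(F)F)cc2)cc1)C(=O)Cn1nnc(-c2ccccc2)n1` is not yet measured. It differs from compound 3 by trifluoromethyl in place of fluoro on an aromatic carbon. Within the data shown here, no measured pair shows this change, so the size of the step is open. Compound 3 already sits at the limit of the assay. The other measured compounds, compound 1 `CCCCCCCCc1ccc(OCC(=O)Cn2nnc(-c3ccc(C(=O)OC)cc3)n2)cc1` with 64% and compound 2 `CCCCCCCCc1ccc(OCC(=O)Cn2nnnc2-c2ccc(C(=O)O)cc2)cc1` with 6%, do not share this change. Compound 4 is expected to stay low, with a step of a number at least 3 percentage points higher from compound 3 to compound 4 (that floor lies within the scatter) that most likely lies within the scatter. The estimate for compound 4 is 8%, between 2% and 25%.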

Compound 4, percent of the compound remaining: 6%
Estimate against measurement, compound 4: 2 percentage points above, and the stated range covers the measured number.
By their numbers in this assay, from the lowest: compounds 2 and 4 (each within the scatter of the next); then compound 1. At a limit, below all of these: compound 3.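

Putting trifluoromethyl in place of fluoro on this aromatic carbon gives, in this assay, a number at least 1 percentage points higher from compound 3 to compound 4 (that floor lies within the scatter). This first pair to differ at this position shows no step beyond the scatter, and compound 4 stays at the low end of the read-out. The true size of the step stays uncertain, because compound 3 rests on a limit of the assay and not on a number: the limit of < 5% in this assay, at which 1 of the 4 values shown sits.

As far as these compounds go, whether a nitrile or an amine at this position would leave more compound intact remains open. So does whether the same change would behave alike on the core of compound 1.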